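The source may report more compounds than this note shows. Statements on the series, on what has been measured and on what is new or still open speak of the compounds shown alone.

Compound 3, `CSc1ccccc1NC(=S)N1CCc2c(sc(NC(=O)c3ccccc3Cl)c2C(N)=O)C1`, is the weakest of the three measured compounds in a functional assay on MKN-74 cells (Homo sapiens) for antiproliferative activity, with a stated time of 24 h (on this read-out lower numbers stand for stronger inhibition and higher numbers for weaker inhibition), where compound 3 gives 13800 nM. Compound 1, `NC(=O)c1c(NC(=O)c2ccccc2Cl)sc2c1CCN(C(=S)Nc1ccccc1F)C2`, gives 12600 nM in this assay, a number that is within the scatter of compound 3, as the step of a 1.1-fold higher number from compound 1 to compound 3 (0.04 log units; within the scatter) shows. Compound 2, `NC(=O)c1c(NC(=O)c2ccccc2Cl)sc2c1CCN(C(=S)Nc1ccccc1I)C2`, gives 2630 nM, and the steps of a 4.8-fold lower number from compound 1 to compound 2 (0.68 log units; beyond the scatter) and a 5.2-fold higher number from compound 2 to compound 3 (0.72 log units; beyond the scatter) are the only ones beyond the scatter in this set.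

Compound 4, `NC(=O)c1c(NC(=O)c2ccccc2Cl)sc2c1CCN(C(=O)Nc1c(Cl)cccc1Cl)C2`, differs from compound 3 in that (a group of 11 heavy atoms (7 carbon, 1 nitrogen, 1 oxygen, 2 chlorine; one six-membered aromatic ring of carbon only) in place of a group of 11 heavy atoms (8 carbon, 1 nitrogen, 2 sulfur; one six-membered aromatic ring of carbon only), on an amine nitrogen in a ring). Within the data shown here, the three measured steps all exchange one substituent on the aromatic ring of that side group while the rest of the group stays the same; none of them exchanges the whole group as the step to compound 4 does, so no measured step bears on it directly. What the measured compounds do show is that changes in this part of the molecule moved the number by at most the size of the step from compound 2 to compound 3 in either direction.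

On that basis the step of a 1.7-fold lower number from compound 3 to compound 4 (0.24 log units; within the scatter) is expected to be small, with direction uncertain. Compound 4 is therefore estimated at 8000 nM in this assay, within a range from 2000 nM to 32000 nM.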

Compound 4, half-maximal inhibitory concentration: 24400 nM
Compound 4: middle estimate off by 3.1-fold (0.48 log units), on the low side; the range from low to high includes it.
By their numbers in this assay, from the lowest: compound 2; then compounds 1, 3 and 4 (each within the scatter of the next).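

In this assay, replacing the whole side group on the amine nitrogen in a ring with (2,6-dichlorophenyl)carbamoyl gives a 1.8-fold higher number from compound 3 to compound 4 (0.25 log units; within the scatter) and a 1.9-fold higher number from compound 1 to compound 4 (0.29 log units; within the scatter), so this exchange of an entire group, with oxygen and two chlorine atoms entering at once, leaves compound 4 level with compound 1 and compound 3 within the scatter. Among these compounds, the same exchange measured against the iodo compound gives a 9.3-fold higher number from compound 2 to compound 4 (0.97 log units; beyond the scatter), the largest step in the set and beyond the scatter, which leaves compound 2 as the only compound set apart from all the others and the strongest of the four. No measurement shown here accounts for these differences.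

The compounds shown leave open how much the exchange of sulfur for oxygen and the two chlorine atoms each contribute, as compound 4 differs from the others in both together. Going by these compounds, it also remains open whether the edge of compound 2 is particular to iodo, or whether a bromo or a methoxy group on the same aromatic ring would give a number like that of compound 2 or like those of the other three.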